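A few compounds are considered here, and "the series" means these few. Any claim that something is new, unique, unknown or untested is made for them only; others in the source may bear on it.

Of the compounds shown here, two from this series have been measured in an assay on cells (Ventricular myocyte) for inhibition of potassium voltage-gated channel subfamily KQT member 1 (Cavia porcellus), read by patch clamp; on this read-out higher numbers stand for weaker inhibition and lower numbers for stronger inhibition. Compound 1 `COc1ccc2c(c1)/C(=N/N1CC(=O)N(CCCCN3CCCCC3)C1=O)CCO2` carries a methoxy group on its aromatic ring, and in this assay compound 1 gives 22000 nM. Compound 2 `CCOc1ccc2c(c1)/C(=N/N1CC(=O)N(CCCCN3CCCCC3)C1=O)CCO2` differs only in that the methoxy has been lengthened to an ethoxy, and in this assay compound 2 gives 1040 nM. That single change produced a 21-fold lower number from compound 1 to compound 2 (1.33 log units; beyond the scatter), so compound 2 stands as the lower of the two numbers, the one with stronger inhibition.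

Compound 3 `CCCOc1ccc2c(c1)/C(=N/N1CC(=O)N(CCCCN3CCCCC3)C1=O)CCO2` continues the same line: the change is methyl in place of hydrogen on a saturated chain carbon, two bonds along the chain from an oxygen on an aromatic ring, so the ethoxy becomes a propoxy. Among the compounds with values here, the only measured step that bears on it is the one from compound 1 to compound 2, which was large. Whether a second lengthening repeats such a gain is not settled by the data, so the expectation is a further decrease in this assay that is more modest, giving an estimated step of a 2.1-fold lower number from compound 2 to compound 3 (0.32 log units; beyond the scatter). On that basis compound 3 is expected to give about 500 nM, with a plausible range from 120 nM to 2500 nM.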

Compound 3, half-maximal inhibitory concentration: 3.2 nM
Compound 3: the middle estimate sits 160-fold (2.19 log units) above what was measured, and the stated range ends above it.
By their numbers in this assay, from the lowest: compound 3; then compound 2; then compound 1.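

In this assay the change from ethoxy to propoxy brings a 330-fold lower number from compound 2 to compound 3 (2.51 log units; beyond the scatter) and this second lengthening therefore does more than the first, which brought a 21-fold lower number from compound 1 to compound 2 (1.33 log units; beyond the scatter) so across these three compounds the number keeps falling and has not levelled off at propoxy. Taken together, going from methoxy to propoxy amounts to a 6900-fold lower number from compound 1 to compound 3 (3.84 log units; beyond the scatter) which shows how strongly the read-out depends on the length of this one chain while the shared core and the rest of the molecule stay the same. Nothing in the data at hand explains why so small an addition has so large an effect.

On these data alone, whether a longer chain such as butoxy or pentyloxy would lower the number further, hold it steady or raise it again remains open. Also open, as far as these compounds go, is whether a branched group such as isopropoxy, or a propoxy chain ending in a hydroxyl group or an amine, would behave like the plain propoxy of compound 3 at this place.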